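Chloro substitution on two pyrazole sulfonamide series

This account rests on a few compounds, and the source may have more. Where it says the series, first, only, none or still open, it means among the compounds named here.

Three compounds were tested in a functional assay on cells (Cancer cell lines, Homo sapiens) for cytotoxicity, read by sulforhodamine B assay, with a stated time of 48 h; a lower number here means a stronger inhibitor of growth, a higher number a weaker inhibitor of growth. Compound 1 `COc1ccc(OC)c(-c2cc(-c3ccccc3)nn2-c2ccc(S(=O)(=O)NC(C)=O)cc2)c1` gives 50700 nM in this assay. Compound 2 `COc1ccc(OC)c(-c2cc(-c3ccc(Cl)cc3)nn2-c2ccc(S(=O)(=O)NC(C)=O)cc2)c1` carries chloro in place of hydrogen on an aromatic carbon relative to compound 1, and in this assay compound 2 gives 67100 nM. The step of a 1.3-fold higher number from compound 1 to compound 2 (0.12 log units; within the scatter) shows that this change left the read-out essentially where it was. Compound 3 `NS(=O)(=O)c1ccc(-n2nc(-c3ccccc3)cc2-c2cc(O)ccc2O)cc1` belongs to a second core; how the two cores differ is not broken down here. In this assay compound 3 gives 98200 nM, a value that lies within the scatter of both compound 1 and compound 2, so no ranking among the three measured compounds is supported.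

Compound 4 `NS(=O)(=O)c1ccc(-n2nc(-c3ccc(Cl)cc3)cc2-c2cc(O)ccc2O)cc1` has not yet been measured. It differs from compound 3 by chloro in place of hydrogen on an aromatic carbon, the same change, at the same kind of place, as that between compound 1 and compound 2. Within the data shown here, since the only measured example of this change, a 1.3-fold higher number from compound 1 to compound 2 (0.12 log units; within the scatter), stayed within the scatter, compound 4 is expected to show a step of a 1.2-fold higher number from compound 3 to compound 4 (0.09 log units; within the scatter) of similar small size, resting on that single precedent and on the fact that the two cores gave values within the scatter of each other. On this basis compound 4 is estimated to give 120000 nM in this assay, with a plausible range from 60000 nM to 240000 nM.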

Compound 4, concentration for total growth inhibition: 50900 nM
Beside the measured number, compound 4's estimate is 2.4-fold (0.37 log units) above it; measured number below the stated range.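

In this assay, the change from phenyl to 4-chlorophenyl on the core of compound 3 gives a 1.9-fold lower number from compound 3 to compound 4 (0.29 log units; within the scatter), so on this core too the step stays inside the usual scatter of repeated measurements. Set beside the earlier step on the core of compound 1, the new step does not differ from it by more than two such steps can differ by chance: the same change on two cores in this assay, a 1.3-fold higher number (0.12 log units; within the scatter) from compound 1 to compound 2 and a 1.9-fold lower number (0.29 log units; within the scatter) from compound 3 to compound 4, 2.6-fold (0.41 log units) apart, within the scatter of two such steps. This shows that in this assay the chloro change behaves alike on the two cores as far as these four compounds can tell, but it does not show a shared effect of the change, since neither step can be told apart from no effect at all, and two pairs at a single place in a single read-out are a thin basis for carrying it to any further core.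

The compounds shown leave open whether a bromo, a methoxy, an amine or a carboxylic acid in place of the chloro, on the same six-membered aromatic ring, would give a step beyond the scatter on either core. They also leave open whether chloro at another place on that ring would behave as it does here.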